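The source may hold more compounds than are shown below. What is called first, only, known or untested is meant among the compounds shown, and "the series" means these compounds.

Working notes on the series, read in a toxicity assay on THP-1 cells (Homo sapiens) for inhibition; on this read-out higher numbers stand for lower toxicity in this test and lower numbers for higher toxicity in this test. Compound 1 (`Cn1c(-c2ccccc2)cnc1NC(=O)c1ccc(F)cc1`) gives > 100000 nM, which is a limit of the assay. Compound 2 (`Cc1ccccc1-c1cnc(NC(=O)c2ccc(F)cc2)n1C`) gives > 50000 nM, which is also a limit, so compound 2 stands without a number of its own. Among the compounds with values here, the one measured step, a step that the two limits leave unreadable from compound 1 to compound 2, has no size to carry forward. Compound 3 (`Cn1c(-c2ccc(Cl)cc2)cnc1NC(=O)c1ccc(F)cc1`) is the next case: 4-chlorophenyl in place of 2-methylphenyl on an aromatic carbon. Here 4-chlorophenyl takes the place of 2-methylphenyl on an aromatic carbon of the shared core. Within the data shown here, no measured step covers this exchange. The limit of compound 2 at > 50000 nM is the only anchor for the expectation, and no shift beyond the scatter can be argued from it. The expected step is a step that the limit leaves unreadable from compound 2 to compound 3. For compound 3 the estimated value is 60000 nM, with an expected range of 25000 nM to 100000 nM.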

Compound 3, half-maximal cytotoxic concentration: 37000 nM
Compound 3: middle estimate off by 1.6-fold (0.21 log units), on the high side; low and high end bracket the measured number.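

Within the data shown here, on an aromatic carbon of the phenyl group, the chloro of compound 3 gives the first reading in this assay that is a number and not a limit. Chloro in place of hydrogen gives an at least 2.7-fold lower number from compound 1 to compound 3 (0.43 log units; beyond the scatter), a shift towards higher toxicity in this test, whereas 4-chlorophenyl in place of 2-methylphenyl gives an at least 1.3-fold lower number from compound 2 to compound 3 (0.13 log units; that floor lies within the scatter), so no shift can be claimed for that exchange. Both steps are floors and not sizes, and the one with chloro in place of hydrogen starts from a limit of the assay: the limit of > 100000 nM in this assay, at which 1 of the 3 values shown sits.

From the compounds shown here alone, the true size of either step stays open, and the step with methyl in place of hydrogen cannot be read. Also open, going by these compounds, is how an amine or a carboxylic acid in place of the chloro would read in this assay.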